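The source may hold more compounds than are shown below. What is called first, only, known or untested is meant among the compounds shown, and "the series" means these compounds.

Measured so far:
- compound 1, `Cc1ccc(NC(=S)NC(=O)Nc2ccc3c(c2)C(=O)C(=O)N3Cc2ccccc2)cc1`, in a physicochemical assay for lipophilicity, in phosphate buffer, measured as octanol-water partition (on this read-out higher numbers stand for higher lipophilicity and lower numbers for lower lipophilicity), compound 1 gives 2.96
- compound 2, `COc1cccc(NC(=S)NC(=O)Nc2ccc3c(c2)C(=O)C(=O)N3Cc2ccccc2)c1`, in this assay compound 2 gives 2.4

Going by the values given here, compound 2 holds the lower of these two numbers; the only measured step, a number 0.56 log units lower from compound 1 to compound 2 (beyond the scatter), separates it from compound 1 and lies beyond the scatter. The unmeasured compound 3, `COc1ccc(NC(=S)NC(=O)Nc2ccc3c(c2)C(=O)C(=O)N3Cc2ccccc2)cc1`, differs from compound 2 only in one way: 4-methoxyphenyl in place of 3-methoxyphenyl on an amide-type nitrogen. Among the compounds with values here, no measured step covers a change of this kind, in which the same atoms are joined differently while the group keeps its name apart from the position in its own name; the step from compound 1 to compound 2 swapped one group for another and does not bear directly on it. With nothing to point in either direction, the expectation is a step that stays within the scatter, no change at the digits printed from compound 2 to compound 3 (within the scatter). Compound 3 is therefore expected to give about 2.4 in this assay, in a range from 2 to 2.8.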

Compound 3, partition coefficient: 2.39
Compound 3: the middle estimate sits 0.01 log units above what was measured; measured number inside the range.
By their numbers in this assay, from the lowest: compounds 3 and 2 (each within the scatter of the next); then compound 1.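

In this assay, putting 4-methoxyphenyl in place of 3-methoxyphenyl on the amide-type nitrogen gives a number 0.01 log units lower from compound 2 to compound 3 (within the scatter), so among these compounds the two named placements of the methoxy group cannot be told apart. Compound 1 and compound 3 differ only by methoxy in place of methyl on an aromatic carbon, and that cleaner comparison gives a number 0.57 log units lower from compound 1 to compound 3 (beyond the scatter), a step of similar size to the earlier one, which had changed the group and its place together. No independent evidence is available to explain either step. On these data alone, whether a longer chain such as ethoxy, or an amine, on that aromatic carbon would give a similar number remains open. So does whether a methyl group would also give matching numbers in the two placements.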